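Swapping trifluoromethyl for cyano on the benzyl ring

The source may hold more compounds than are shown below. What is called first, only, known or untested is meant among the compounds shown, and "the series" means these compounds.

Of the compounds shown here, two sharing one core have been tested in an assay on isolated protein for inhibition of Long-chain-fatty-acid--CoA ligase 1 (Mus musculus), read by mass spectrometry, with a stated time of 90 min, in the presence of a further agent that is not named here; on this read-out lower numbers stand for stronger inhibition and higher numbers for weaker inhibition. Compound 1 `Cc1ccc(Cc2nc3cc(O[C@H]4CC[C@@H](C(=O)O)CC4)ccc3n2C)cc1` gives 80 nM in this assay. Compound 2 `Cn1c(Cc2cccc(C(F)(F)F)c2)nc2cc(O[C@H]3CC[C@@H](C(=O)O)CC3)ccc21` gives 86 nM in this assay. The only structural difference between them is the aromatic group on the saturated chain carbon, and the step of a 1.1-fold higher number from compound 1 to compound 2 (0.03 log units; within the scatter) shows that exchanging one substituted phenyl ring for another left the number essentially where it was. Among the two numbers available, compound 2 stands with the higher one, but its nearest neighbour, compound 1, sits within the scatter, so no order can be read from them.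

Compound 3 `Cn1c(Cc2cccc(C#N)c2)nc2cc(O[C@H]3CC[C@@H](C(=O)O)CC3)ccc21` differs from compound 2 by one change: cyano in place of trifluoromethyl on an aromatic carbon. Going by the values given here, the only step that bears on this change, a 1.1-fold higher number from compound 1 to compound 2 (0.03 log units; within the scatter), was within the scatter, and it altered the same aromatic ring more broadly than this step does. On that basis, no step beyond the scatter is expected in this assay. Compound 3 is therefore estimated at 95 nM in this assay, within a range of 40 nM to 250 nM, which means an expected step of a 1.1-fold higher number from compound 2 to compound 3 (0.04 log units; within the scatter).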

Compound 3, half-maximal inhibitory concentration: 22000 nM
Compound 3: middle estimate off by 230-fold (2.36 log units), on the low side; the measured number lies above the stated range.
By their numbers in this assay, from the lowest: compounds 1 and 2 (each within the scatter of the next); then compound 3.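

In this assay, the earlier pair suggested that the aromatic group on the chain carbon could change with little effect, yet cyano in place of trifluoromethyl on an aromatic carbon gives a 260-fold higher number from compound 2 to compound 3 (2.41 log units; beyond the scatter) and shows that this position is far from indifferent to the group it carries. The exchange of 3-cyanophenyl for 4-methylphenyl gives a similar result, a 280-fold higher number from compound 1 to compound 3 (2.44 log units; beyond the scatter), while compound 2, which carries trifluoromethyl at the same place, stays within the scatter of compound 1, so the mere presence of a group there does not bring the loss and the identity of the group matters. No measurement available here explains why these two small groups differ so sharply in this assay.

The compounds shown leave open whether the loss is specific to the nitrile or would also appear with other groups at this place, such as a methoxy group, a chlorine atom or a primary amide. They also leave open whether a cyano group in place of the methyl on the ring of compound 1 would bring a step of similar size.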